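Ethyl to isopropyl: from compound 2 to compound 3

The compounds below may be only part of what the source reports. "The series", "measured", "known", "first", "only" and "open" are said of these compounds alone.

In an ADME assay on a cell-free system (plasma, Homo sapiens) for metabolic stability, read by LC-MS, with a stated time of 60 min, tested at 10 uM (a higher number here means that more of the compound is left, a lower number that less of the compound is left), compound 1 `CC(C)[C@H](N)C(=O)N[C@@H](CCC(=O)C=[N+]=[N-])C(=O)OCc1c[nH]c2ccccc12` gives 30% and compound 2 `CCC(OC(=O)N[C@@H](CCC(=O)C=[N+]=[N-])C(=O)OC)OC(=O)C(C)(C)C` gives 88% as the higher of the two numbers. For the measured compounds named here, the gap between them lies beyond the scatter, and compound 2 therefore stands at the top of the series so far. Compound 3 `COC(=O)[C@H](CCC(=O)C=[N+]=[N-])NC(=O)OC(OC(=O)C(C)(C)C)C(C)C` differs from compound 2 by methyl in place of hydrogen on a saturated chain carbon bound to two saturated chain carbons in a single place: methyl in place of hydrogen on a saturated chain carbon bound to two saturated chain carbons, which turns ethyl into isopropyl. Going by the values given here, no measured pair differs in one place, so the data offer no direct precedent for this change. Compound 2 at 88% already sits high on the read-out. The expected result is a number 1 percentage points higher from compound 2 to compound 3 (within the scatter) in this assay and no change beyond the scatter. Compound 3 is estimated at 89% with an expected range from 76% to 100% on repeat measurement.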

Compound 3, percent of the compound remaining: 91%
For compound 3 the middle estimate is 2 percentage points below the measured one; measured number inside the range.
By their numbers in this assay, from the lowest: compound 1; then compounds 2 and 3 (each within the scatter of the next).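

In this assay, for the compounds shown here, the step is a number 3 percentage points higher from compound 2 to compound 3 (within the scatter), the first pair that differs in one place. Going by these compounds alone, it gives the first direct reading at this position: methyl in place of hydrogen on a saturated chain carbon bound to two saturated chain carbons, which turns ethyl into isopropyl, produces no difference beyond the scatter in percent of the compound remaining. No measured information bears on why the two compounds read alike.

As far as these compounds go, what a longer chain such as n-butyl, a phenyl group or an amine would give at this position remains open. A single step also leaves open whether methyl in place of hydrogen would read the same way on another core.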